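A few compounds are considered here, and "the series" means these few. Any claim that something is new, unique, unknown or untested is made for them only; others in the source may bear on it.

Of the compounds shown here, three that share one core have been measured. Compound 1 `O=C1C=C(Nc2ccc(I)cc2)C(=O)c2c1nc1n2[C@H]2OC[C@@H](O)[C@H]2OC1` gives 1400 nM in a functional assay on MGC-803 cells (Homo sapiens) for inhibition, read by sulforhodamine B assay (a higher number here means a weaker inhibitor, a lower number a stronger inhibitor), the lowest of the three numbers; compound 3 `Cc1ccc(NC2=CC(=O)c3c(nc4n3[C@H]3OC[C@@H](O)[C@H]3OC4)C2=O)cc1` gives 1550 nM and compound 2 `CCOc1ccc(NC2=CC(=O)c3c(nc4n3[C@H]3OC[C@@H](O)[C@H]3OC4)C2=O)cc1` gives 2090 nM, both within the scatter of compound 1. For the measured compounds named here, the only measured step, a 1.3-fold lower number from compound 2 to compound 3 (0.13 log units; within the scatter), changes a group on an aromatic ring and stays within the scatter. Compound 4 `O=C1C=C(NC2CCCCC2)C(=O)c2c1nc1n2[C@H]2OC[C@@H](O)[C@H]2OC1` carries a different kind of change: cyclohexyl in place of 4-iodophenyl on an amine nitrogen. Going by the values given here, no measured step bears on this exchange, since every measured compound keeps an aromatic group on that nitrogen, so the data give no guide to its size or direction. Compound 4 is therefore expected at 2500 nM, with a wide range from 600 nM to 10000 nM. That expectation amounts to an estimated step of a 1.8-fold higher number from compound 1 to compound 4 (0.25 log units; within the scatter) in this assay.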

Compound 4, half-maximal inhibitory concentration: > 8000 nM
Compound 4: no number, only a limit (the forecaster's own chance of this, stated with the estimate: 5%); at least 3.2-fold (0.50 log units) between middle value and limit.
By their numbers in this assay, from the lowest: compounds 1, 3 and 2 (each within the scatter of the next). At a limit, above all of these: compound 4.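

Exchanging the aromatic group on this amine nitrogen is the first change shown to go beyond the scatter: in this assay the step is an at least 5.7-fold higher number from compound 1 to compound 4 (0.75 log units; beyond the scatter). For the compounds shown here, compound 4 gives no number, only a limit of the assay: the limit of > 8000 nM in this assay, at which 1 of the 4 values shown sits. The earlier compounds all keep an aromatic ring on this nitrogen, and only this pair shows that a six-membered non-aromatic ring of carbon does not match it there. Going by these compounds, how far compound 4 lies past its limit stays open. Also open, on these data alone, is how a benzyl group, a morpholine or a straight butyl chain on that nitrogen would compare.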